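Compound 4: methoxy in place of chloro on the aryl amide

The compounds below may be only part of what the source reports. "The series", "measured", "known", "first", "only" and "open" are said of these compounds alone.

Three compounds of the series have been run in a functional assay on T47D cells (Homo sapiens) for inhibition, read by CCK-8 assay, with a stated time of 72 h, tested at 10 uM; on this read-out lower numbers stand for less inhibition of growth and higher numbers for more inhibition of growth at the one concentration tested. Compound 1 `CN(C)C(=O)c1cc2cnc(Nc3ccc(NC(=O)C4(C(=O)Nc5ccccc5)CC4)cc3)nc2n1C1CCCC1` gives 93.9%. Compound 2 `CN(C)C(=O)c1cc2cnc(Nc3ccc(NC(=O)C4(C(=O)Nc5cccc(F)c5)CC4)cc3)nc2n1C1CCCC1` gives -0.4%. Compound 3 `CN(C)C(=O)c1cc2cnc(Nc3ccc(NC(=O)C4(C(=O)Nc5ccc(Cl)cc5)CC4)cc3)nc2n1C1CCCC1` gives 95%, the highest of the three numbers; its nearest neighbour is compound 1, a number 1.1 percentage points higher from compound 1 to compound 3 (within the scatter), which lies within the scatter, while compound 2 sits far below, a number 95.4 percentage points higher from compound 2 to compound 3 (beyond the scatter).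

Compound 4 `COc1ccc(NC(=O)C2(C(=O)Nc3ccc(Nc4ncc5cc(C(=O)N(C)C)n(C6CCCC6)c5n4)cc3)CC2)cc1` differs from compound 3 in one place: methoxy in place of chloro on an aromatic carbon. Going by the values given here, no measured step touches a methoxy group, so the bearing steps are indirect. Adding chloro to the unsubstituted parent, a number 1.1 percentage points higher from compound 1 to compound 3 (within the scatter), changed nothing beyond the scatter, whereas the other substitution made on this ring, a number 94.3 percentage points lower from compound 1 to compound 2 (beyond the scatter), removed growth inhibition almost entirely. The series thus shows that a substituent on this ring can be tolerated or can abolish activity, and nothing separates the two outcomes.

The expectation for compound 4 in this assay is therefore a value close to compound 3, an estimated step of a number 8 percentage points lower from compound 3 to compound 4 (within the scatter), with a wide lower margin to allow for a collapse of the kind seen with compound 2. Compound 4 is estimated at 87%, range 40% to 100%.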

Compound 4, percent growth inhibition at one concentration: 96.1%
Estimate against measurement, compound 4: 9.1 percentage points below, and the stated range covers the measured number.
By their numbers in this assay, from the lowest: compound 2; then compounds 1, 3 and 4 (each within the scatter of the next).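

In this assay the place para to a large group on the aryl amide ring now accepts a second, quite different substituent: a number 1.1 percentage points higher from compound 3 to compound 4 (within the scatter) and a number 2.2 percentage points higher from compound 1 to compound 4 (within the scatter) are both steps that leave hydrogen, chloro and methoxy indistinguishable on this read-out. Exchanging chloro for methoxy brings in oxygen and a hydrogen-bond acceptor, and neither addition moves the number at the one concentration tested. Going by these compounds alone, the gap to the 3-fluorophenyl analogue stays just as wide with the new group, as a number 96.5 percentage points higher from compound 2 to compound 4 (beyond the scatter) shows, so compound 2 remains the one compound against tolerance of substitution on this ring, and it alone carries its substituent at the 3-position of the phenyl. No measured evidence accounts for the difference between these outcomes.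

Still open, as far as these compounds go, is whether the collapse of compound 2 follows from the 3-position or from fluoro itself, which a 3-methoxyphenyl or 3-chlorophenyl analogue would separate. Also open, from the compounds shown here alone, is whether the 4-position tolerates an amine, a carboxylic acid or a longer alkoxy chain, and a single-concentration read-out cannot separate compound 1, compound 3 and compound 4 from one another.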